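This account rests on a few compounds, and the source may have more. Where it says the series, first, only, none or still open, it means among the compounds named here.

Compound 1 `O=C(NCCNS(=O)(=O)c1ccc(-c2ccccc2O[C@H]2CC[C@H](O)CC2)s1)Nc1cc(Cl)cc(Cl)c1` — in a functional assay on HeLa cells (Homo sapiens) for inhibition, read by CCK-8 assay, with a stated time of 48 h (on this read-out higher numbers stand for weaker inhibition and lower numbers for stronger inhibition), compound 1 gives > 20000 nM, which is a limit of the assay rather than a number.
Compound 2 `O=[N+]([O-])c1cccc(NC(=S)NCCNS(=O)(=O)c2ccc(-c3ccccc3OCc3ccccc3)s2)c1` — in this assay compound 2 gives 12800 nM.
Compound 3 `COc1ccc(NC(=O)NCCNS(=O)(=O)c2ccc(-c3ccccc3Oc3ccc([N+](=O)[O-])cc3)s2)cc1` — in this assay compound 3 gives > 20000 nM, again a limit and not a number.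

Compound 1 therefore has no measured value of its own in this assay, only a limit, and it shares that position with compound 3, as the evidence the limit of > 20000 nM in this assay, at which 2 of the 3 values shown sit, makes plain. Among the measured compounds shown here, compound 2 is the one compound of the three with a number, and even that number is weak.

The next compound, compound 4 `O=C(NCCNS(=O)(=O)c1ccc(-c2ccccc2Oc2ccc([N+](=O)[O-])c([N+](=O)[O-])c2)s1)Nc1cc(Cl)cc(Cl)c1`, comes from compound 1 through one change: 3,4-dinitrophenyl in place of 4-hydroxycyclohexyl on an oxygen on an aromatic ring. For the measured compounds named here, no step between two measured compounds carries this change, so nothing measured tells how large a move it brings. Compound 3 also carries a nitrophenyl on the ring oxygen and sits at the limit, which gives little reason to expect a move beyond the scatter. Compound 4 is expected at about 20000 nM, between 8000 nM and 50000 nM. The expected step of a number no higher from compound 1 to compound 4 (the limit leaves the size open) is estimated to be small, most likely leaving compound 4 at the limit too.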

Compound 4, half-maximal inhibitory concentration: > 20000 nM
Compound 4: no number, only a limit (the forecaster's own chance of this, stated with the estimate: 60%); the middle value sits exactly at the limit.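

In this assay compound 4 gives > 20000 nM, a limit and not a number. Among the compounds shown here, compound 1 also has only a limit, so no step between compound 1 and compound 4 can be read. The compounds shown leave open what size of change this replacement brings.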